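Smaller Amine on the Side Chain: Compounds 3 and 4

A few compounds are considered here, and "the series" means these few. Any claim that something is new, unique, unknown or untested is made for them only; others in the source may bear on it.

Compound 1 `CCn1c(C(=O)NCCCN(C)C)ccc1C(CC)(CC)c1ccc(OCC(=O)C(C)(C)C)c(C)c1` and compound 2 `CCN(CC)CCCNC(=O)c1ccc(C(CC)(CC)c2ccc(OCC(=O)C(C)(C)C)c(C)c2)n1CC` share one core and differ only at the terminal amine. In a functional assay on Caco-2 cells (Homo sapiens), read by MTT assay, with a stated time of 48 h (on this read-out higher numbers stand for weaker inhibition and lower numbers for stronger inhibition), compound 2 gives 1000 nM and compound 1 gives 1400 nM; the change dimethylamino in place of diethylamino on a saturated chain carbon, three bonds along the chain from an amide-type nitrogen made a step of a 1.4-fold higher number from compound 2 to compound 1 (0.15 log units; within the scatter). Compound 3 `CCN(CC)CCNC(=O)c1ccc(C(CC)(CC)c2ccc(OCC(O)C(C)(C)C)c(C)c2)n1CC` gives 2310 nM in this assay; the difference between its core and that of compound 2 is not broken down here. Compound 4 `CCn1c(C(=O)NCCN(C)C)ccc1C(CC)(CC)c1ccc(OCC(O)C(C)(C)C)c(C)c1` has not yet been measured. It carries the same kind of change, (dimethylamino in place of diethylamino on a saturated chain carbon, two bonds along the chain from an amide-type nitrogen), though here on a saturated chain carbon two bonds along the chain from an amide-type nitrogen rather than three. The earlier step of a 1.4-fold higher number from compound 2 to compound 1 (0.15 log units; within the scatter) stayed within the scatter, and a similar outcome is expected here. From compound 3 the expected step is a 1.3-fold higher number from compound 3 to compound 4 (0.11 log units; within the scatter). Compound 4 is thus estimated at 3000 nM, with a range from 1500 nM to 6000 nM.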

Compound 4, half-maximal inhibitory concentration: 1300 nM
For compound 4 the middle estimate is 2.3-fold (0.36 log units) above the measured one, outside the stated range (below it).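

Dimethylamino in place of diethylamino, on a saturated chain carbon two bonds along the chain from an amide-type nitrogen, makes a 1.8-fold lower number from compound 3 to compound 4 (0.25 log units; within the scatter) in this assay, so this step stays small. Set beside the earlier step, it shows no difference that exceeds the scatter: the same change on two cores in this assay, a 1.4-fold higher number (0.15 log units; within the scatter) from compound 2 to compound 1 and a 1.8-fold lower number (0.25 log units; within the scatter) from compound 3 to compound 4, 2.5-fold (0.40 log units) apart, within the scatter of two such steps. The change can thus be carried between these two cores without a shift beyond the scatter in either case, but two pairs establish no consistent direction and do not show how it would behave on any other core.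

The compounds shown leave open how a ring amine such as piperidine or morpholine would compare at the end of the chain. They also leave open what a longer chain would do when carrying either dimethylamino or diethylamino.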